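Swapping the halogen-bearing ring on the sulfur of compound 2

The source may report more compounds than this note shows. Statements on the series, on what has been measured and on what is new or still open speak of the compounds shown alone.

Of the compounds shown here, three that share a core have so far been measured. Compound 1 `COc1ccc(SCc2ccc(/C=C/C(=O)Nc3ccccc3N)cc2)cc1OC`, in a functional assay on HCT-116 cells (Homo sapiens) for inhibition, read by CCK-8 assay, with a stated time of 72 h, tested at 8 uM (a lower number here means less inhibition of growth, a higher number more inhibition of growth at the concentration tested), gives 49.5%. Compound 2 `Nc1ccccc1NC(=O)c1ccc(CSc2ccc(Br)cc2)cc1` gives 67.7% in this assay, the highest of the three numbers, and the gap to compound 1 lies beyond the scatter of repeated measurements. Compound 3 `Nc1ccccc1NC(=O)c1ccc(CSc2ccc(C(F)(F)F)cn2)cc1` gives 25.8% in this assay, the lowest number, again separated from compound 2 by more than the scatter.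

Compound 4 `Nc1ccccc1NC(=O)c1ccc(CSc2cccc(F)c2)cc1` has not yet been measured. It differs from compound 2 in one place: 3-fluorophenyl in place of 4-bromophenyl on a sulfur. Within the data shown here, no pair of measured compounds differs in exactly this way, so there is no measured step to lean on. The other two compounds, which differ from compound 2 in other places, both sit lower, so a modest fall is expected rather than a rise. The step expected from this change is a number 15.7 percentage points lower from compound 2 to compound 4 (beyond the scatter) in this assay, a drop that may or may not exceed the scatter. Compound 4 is expected to give about 52% in this assay. The estimate for compound 4 spans from 32% to 70%.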

Compound 4, percent growth inhibition at one concentration: 81.4%
The estimate for compound 4 lay 29.4 percentage points below the measured number; measured number outside the range, above it.
By their numbers in this assay, from the lowest: compound 3; then compound 1; then compound 2; then compound 4.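

Putting 3-fluorophenyl in place of 4-bromophenyl on the sulfur gives a number 13.7 percentage points higher from compound 2 to compound 4 (beyond the scatter) in this assay, so this position accepts a change of ring substituent and growth inhibition can even rise. The 4-bromophenyl of compound 2 is therefore not required for the inhibition seen at the concentration tested. The data offer no explanation for this rise.

This single step changes both the halogen and its place on the ring, so the compounds shown cannot tell which of the two matters. From the compounds shown here alone, an unsubstituted phenyl, 4-fluorophenyl or 3-bromophenyl on the sulfur would separate these two changes, and how an amine or a carboxylic acid on this ring would behave remains open.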